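The source may report more compounds than this note shows. Statements on the series, on what has been measured and on what is new or still open speak of the compounds shown alone.

Working notes on the series. Compound 1 `O=C(Nc1ccc(Cl)c(-c2nnc3c(Cl)cccn23)c1)c1ccc(C(F)(F)F)cc1F`, compound 2 `CS(=O)(=O)c1ccc(C(=O)Nc2ccc(Cl)c(-c3nnc4c(Cl)cccn34)c2)c(Cl)c1` and compound 3 `O=C(Nc1ccc(Cl)c(-c2nnc3c(Cl)cccn23)c1)c1c(F)cccc1Cl` share one core and differ only in the acyl group on the amide. In a functional assay on MDA-MB-468 cells (Homo sapiens) for antiproliferative activity, read by MTT assay, with a stated time of 72 h (a higher number here means a weaker inhibitor, a lower number a stronger inhibitor), compound 1 gives 22300 nM. In this assay compound 2 returns only a limit, > 100000 nM, and not a number. In this assay compound 3 gives 57600 nM, the highest of the two numbers in hand; the nearest is compound 1, whose lower number sits beyond the scatter. Compound 2 contributes only a limit in this assay (the limit of > 100000 nM in this assay, at which 1 of the 3 values shown sits). For the measured compounds named here, no step between two measured compounds is directly comparable here, so the two numbers are simply noted side by side.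

Compound 4 `O=C(Nc1ccc(Cl)c(-c2nnc3c(Cl)cccn23)c1)c1ccon1` is not yet measured in this assay. It differs from compound 3 as follows (1,2-oxazol-3-yl in place of 2-chloro-6-fluorophenyl on a carbonyl carbon). Going by the values given here, with only weak numbers and no matched step to lean on, the step is expected to be modest a 1.9-fold lower number from compound 3 to compound 4 (0.28 log units; within the scatter), toward a somewhat lower number. For compound 4 the estimated value in this assay is 30000 nM, within a range of 8000 nM to 100000 nM.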

Compound 4, half-maximal inhibitory concentration: > 100000 nM
Compound 4 gave a limit, no number (the forecaster's own chance of this, stated with the estimate: 25%); middle value at least 3.3-fold (0.52 log units) from the limit.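

In this assay, for the compounds shown here, compound 4 returns only a limit and not a number, and replacing 2-chloro-6-fluorophenyl with 1,2-oxazol-3-yl on the carbonyl carbon gives the first readable step at this position: an at least 1.7-fold higher number from compound 3 to compound 4 (0.23 log units; that floor lies within the scatter). This change does not bring a lower number, but the floor of the step lies within the scatter, so neither its full size nor a real rise is established. Compound 4 joins compound 2 at the limit, leaving the numbers in this series bounded at the top: the limit of > 100000 nM in this assay, at which 2 of the 4 values shown sit.

The compounds shown leave open whether a pyridine ring or a plain alkyl chain on the carbonyl carbon would give a measurable number in this assay and how it would compare with the values in hand. They also leave open whether the step follows from the five-membered ring itself or from the loss of the chlorine and fluorine, since both changes come together here.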